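The source may report more compounds than this note shows. Statements on the series, on what has been measured and on what is new or still open speak of the compounds shown alone.

Of the compounds shown here, two have so far been tested in an ADME assay on Vero cells (Chlorocebus sabaeus) for cytotoxicity, read by microscopy, with a stated time of 6 days; a higher number here means that more compound is tolerated, a lower number that less compound is tolerated. Compound 1 `CCCCNc1cnc(C(=O)NCc2ccccc2)cn1` reaches only the limit > 100000 nM, which is a limit of the assay and not a number. Compound 1 sits at the limit of > 100000 nM in this assay, at which 1 of the 2 values shown sits. Among the measured compounds shown here, compound 2 `CCCCCCNc1cncc(C(=O)NCc2ccccc2)n1` gives 100000 nM, the only number in this assay to date. For the measured compounds named here, with no step between measured compounds on record, there is no measured guide for the next change. Compound 3 `CCCCCCCCNc1cncc(C(=O)NCc2ccccc2)n1` differs from compound 2 by ethyl in place of hydrogen on a saturated chain carbon, six bonds along the chain from a nitrogen on an aromatic ring. A small decrease in tolerated concentration is expected, a 1.7-fold lower number from compound 2 to compound 3 (0.22 log units; within the scatter), perhaps not beyond the scatter. Compound 3 is estimated at 60000 nM in this assay, within 25000 nM to 100000 nM.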

Compound 3, minimum cytotoxic concentration: > 100000 nM
Compound 3: a limit, no number (the forecaster's own chance of this, stated with the estimate: 30%); middle value at least 1.6-fold (0.22 log units) away from the limit.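

Ethyl in place of hydrogen on a saturated chain carbon, six bonds along the chain from a nitrogen on an aromatic ring, gives in this assay a number no lower from compound 2 to compound 3 (the limit leaves the size open) and the size of this step cannot be read. This change at this position therefore brings no measured loss of tolerated concentration. The reading of compound 3 is a limit and not a number, and it stands at the ceiling of the assay: the limit of > 100000 nM in this assay, at which 2 of the 3 values shown sit.

From the compounds shown here alone, whether a longer chain, or an amine or carboxylic acid in place of the chain, would give a number under this limit stays open. Going by these compounds, how far the tolerated concentration of compound 3 lies from that of compound 2 also stays open.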